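Swapping one aryl group on a level pair

The source may report more compounds than this note shows. Statements on the series, on what has been measured and on what is new or still open speak of the compounds shown alone.

Measured compounds:
- compound 1 `COc1ccccc1/C=C(\C(=O)c1ccc(Cl)cc1)S(=O)(=O)Cc1ccc(Cl)c(Cl)c1`: 1000 nM
- compound 2 `Cc1ccc(CS(=O)(=O)/C(=C/c2cccc(Cl)c2Cl)C(=O)c2ccc(Cl)cc2)cc1`: 1000 nM

In a functional assay on DU-145 cells (Homo sapiens) for inhibition, read by trypan blue exclusion, with a stated time of 96 h (on this read-out higher numbers stand for weaker inhibition of growth and lower numbers for stronger inhibition of growth), compound 2 gives 1000 nM, which is level with compound 1 at 1000 nM. The two values lie within the scatter of each other, so neither compound can be placed ahead of the other.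

The next compound to be tested is compound 3 `COc1ccccc1/C=C(\C(=O)c1ccc(Cl)cc1)S(=O)(=O)Cc1ccc(C)cc1`. It differs from compound 2 in one place: 2-methoxyphenyl in place of 2,3-dichlorophenyl on a double-bonded chain carbon bound to a double-bonded chain carbon. This puts 2-methoxyphenyl in place of 2,3-dichlorophenyl on a double-bonded chain carbon bound to a double-bonded chain carbon.

Going by the values given here, no measured pair isolates this change, so the data give no direct size for it. Among the compounds with values here, the only guide is that compound 1 already carries 2-methoxyphenyl and gives 1000 nM, the same reading as compound 2. On that basis, no step beyond the scatter is expected in this assay, in either direction.

This expectation corresponds to an estimated step of no change at the digits printed from compound 2 to compound 3 (within the scatter). The expected value for compound 3 is 1000 nM, with an estimated range of 400 nM to 2500 nM.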

Compound 3, concentration for 50% growth inhibition: 10000 nM
Estimate against measurement, compound 3: 10-fold (1.00 log units) below; measured number above the stated range.
By their numbers in this assay, from the lowest: compounds 1 and 2 (each within the scatter of the next); then compound 3.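

The two steps show that both places matter, which the level pair could not show, since compound 1 and compound 2 differ in two places at once. In this assay, with 4-methylphenyl held on the saturated chain carbon bound to a sulfonyl sulfur, 2-methoxyphenyl in place of 2,3-dichlorophenyl on a double-bonded chain carbon bound to a double-bonded chain carbon gives a 10-fold higher number from compound 2 to compound 3 (1.00 log units; beyond the scatter). With 2-methoxyphenyl held at that place, 4-methylphenyl in place of 3,4-dichlorophenyl on the saturated chain carbon gives a 10-fold higher number from compound 1 to compound 3 (1.00 log units; beyond the scatter), so among these three compounds only compound 3, which carries neither dichlorophenyl group, stands apart from the others.

Nothing shown here gives a reason for either step. Still open, as far as these compounds go, are how a compound carrying both dichlorophenyl groups would read, and whether a single chlorine, a 2-hydroxyphenyl group or a pyridine ring at either place would follow the dichlorophenyl compounds or compound 3.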